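The compounds below may be only part of what the source reports. "The series", "measured", "known", "first", "only" and "open" are said of these compounds alone.

Among the compounds with values here, in a functional assay (Homo sapiens) for inhibition (a higher number here means a weaker inhibitor, a lower number a stronger inhibitor), compound 1 `COc1cc(/C=C/C(=O)c2ccc([N+](=O)[O-])cc2)cc(OC)c1` gives 20000 nM, the higher of the two numbers so far, which makes it the weaker inhibitor of the pair. Compound 2 `COc1cc(/C=C/C(=O)c2ccccc2O)cc(OC)c1` gives 8100 nM. Compound 3 `CCCCOc1ccc(C(=O)/C=C/c2cc(OC)cc(OC)c2)cc1` carries butoxy in place of nitro on an aromatic carbon, para to a large group: butoxy in place of nitro on an aromatic carbon. Within the data shown here, no measured pair isolates this change, so the expectation is loose. A modest step toward a lower number is expected in this assay, estimated as a 2.0-fold lower number from compound 1 to compound 3 (0.30 log units; within the scatter). For compound 3 the estimated value is 10000 nM, with an expected range of 3000 nM to 30000 nM.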

Compound 3, half-maximal inhibitory concentration: 52000 nM
Beside the measured number, compound 3's estimate is 5.2-fold (0.72 log units) below it; measured number above the stated range.
By their numbers in this assay, from the lowest: compound 2; then compound 1; then compound 3.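

In this assay the exchange of butoxy for nitro on an aromatic carbon, para to a large group, gives a 2.6-fold higher number from compound 1 to compound 3 (0.41 log units; beyond the scatter) and so moves toward weaker inhibition. Within the data shown here, this is the first measured single change, and it shows that this position is not indifferent to its substituent, with nitro the better of the two groups. Nothing at hand accounts for the step. Open, from the compounds shown here alone, is whether an amine or a carboxylic acid here would give a lower number. Also open, going by these compounds, is how a shorter alkoxy chain such as ethoxy or a longer one such as hexyloxy would compare with butoxy.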